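The source may report more compounds than this note shows. Statements on the series, on what has been measured and on what is new or still open speak of the compounds shown alone.

Measured so far in an ADME assay on PBMC cells (Homo sapiens) for cytotoxicity; on this read-out higher numbers stand for lower toxicity in this test and lower numbers for higher toxicity in this test:
- compound 1, `CC(CCNC(=O)c1c(Cl)cncc1Cl)N1CCC(C(Oc2ccccn2)c2ccc(C(F)(F)F)cc2)CC1`, gives 34100 nM
- compound 2, `CC(CCNC(=O)c1c(Cl)cncc1Cl)N1CCC(C(Oc2cc(Cl)ccn2)c2ccc(C(F)(F)F)cc2)CC1`, gives 4260 nM
- compound 3, `CC(CCNC(=O)c1c(Cl)cncc1Cl)N1CCC(C(Oc2ccccc2C(F)(F)F)c2ccc(C(F)(F)F)cc2)CC1`, gives 12500 nM

Among these three, compound 3 stands in the middle: its number lies a 2.7-fold lower number from compound 1 to compound 3 (0.44 log units; beyond the scatter), and a 2.9-fold higher number from compound 2 to compound 3 (0.47 log units; beyond the scatter). The next compound to consider is compound 4, `CC(CCNC(=O)c1c(Cl)cncc1Cl)N1CCC(C(Oc2cccc(Cl)n2)c2ccc(C(F)(F)F)cc2)CC1`, which is not yet measured. It differs from compound 3 in one place: 6-chloropyridin-2-yl in place of 2-(trifluoromethyl)phenyl on an oxygen on a saturated carbon.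

Within the data shown here, two measured steps bear on this change. The step of a 2.9-fold higher number from compound 2 to compound 3 (0.47 log units; beyond the scatter) is close to the reverse of what happens here, since compound 2 carries 4-chloropyridin-2-yl on that oxygen rather than 6-chloropyridin-2-yl. The step of an 8.0-fold lower number from compound 1 to compound 2 (0.90 log units; beyond the scatter) shows that putting chloro onto the pyridin-2-yl ring moved the number down markedly. Among the measured compounds shown here, both point the same way: swapping 2-(trifluoromethyl)phenyl back for a chloro-bearing pyridin-2-yl is expected to lower the number beyond the scatter, by roughly a 2.3-fold lower number from compound 3 to compound 4 (0.36 log units; beyond the scatter), a modest step, though no measured pair shows 6-chloropyridin-2-yl itself. Compound 4 is therefore estimated at 5500 nM, with a likely range from 2000 nM to 15000 nM.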

Compound 4, half-maximal cytotoxic concentration: > 32500 nM
Compound 4: a limit, no number; the forecaster's own chance of this, stated with the estimate: 5%; middle value at least 5.9-fold (0.77 log units) away from the limit.
By their numbers in this assay, from the lowest: compound 2; then compound 3; then compound 1.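

In this assay compound 4 gives > 32500 nM, which is a limit of the assay and not a number: the limit of > 32500 nM in this assay, at which 1 of the 4 values shown sits.

This result shows that adding chloro to the pyridin-2-yl ring on this oxygen has no single outcome, since moving it from the arrangement in 4-chloropyridin-2-yl to that in 6-chloropyridin-2-yl gives an at least 7.6-fold higher number from compound 2 to compound 4 (0.88 log units; beyond the scatter), and so where the chloro sits matters in this series. It also reverses the direction suggested by compound 2. 6-chloropyridin-2-yl in place of 2-(trifluoromethyl)phenyl gives an at least 2.6-fold higher number from compound 3 to compound 4 (0.41 log units; beyond the scatter). On these data alone, the step between compound 1 and compound 4 cannot be read, so it remains unknown whether 6-chloropyridin-2-yl differs at all from the plain pyridin-2-yl.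

Only chloro has been shown on the pyridine ring, so it remains open whether a methyl, a methoxy or a nitrile would show the same dependence on where it sits. How an amine or a carboxylic acid on this ring would read in this assay also stays unanswered.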